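Adding 4-methylpiperazin-1-yl to compound 2

The compounds below may be only part of what the source reports. "The series", "measured", "known", "first", "only" and "open" are said of these compounds alone.

Measured in a physicochemical assay for solubility, using the shake flask method, measured as kinetic solubility, with a stated time of 2 h, at pH 7.4; a higher number here means a more soluble compound, a lower number a less soluble compound:
Compound 1 `CN(Cc1cccnc1)c1cc(C(=O)Nc2ccccc2)ncn1`: 150000 nM
Compound 2 `CN(Cc1ccc(C(F)(F)F)nc1)c1cc(C(=O)Nc2ccccc2)ncn1`: < 5000 nM (a limit)
Compound 3 `COc1ccc(NC(=O)c2cc(N(C)Cc3ccc(Cl)cc3)nc(NC3CC3)n2)cc1`: 5000 nM

In this assay compound 2 reads < 5000 nM, which is a limit and not a number. This is the limit of < 5000 nM in this assay, at which 1 of the 3 values shown sits.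

Compound 4 `CN1CCN(c2ccc(NC(=O)c3cc(N(C)Cc4ccc(C(F)(F)F)nc4)ncn3)cc2)CC1` differs from compound 2 in one place: 4-methylpiperazin-1-yl in place of hydrogen on an aromatic carbon. In words, 4-methylpiperazin-1-yl stands in place of hydrogen on an aromatic carbon.

For the measured compounds named here, only one measured step bears on this, and only indirectly: an at least 30-fold lower number from compound 1 to compound 2 (1.47 log units; beyond the scatter). That large step came from a different change, trifluoromethyl in place of hydrogen on an aromatic carbon, so it shows how far one change can move the solubility of these compounds but does not set the direction here. A moderate rise in this assay, smaller than that step, is expected, and a reading that is only a limit remains possible. The estimated step is an at least 3.0-fold higher number from compound 2 to compound 4 (0.47 log units; beyond the scatter). For compound 4 the estimate is 15000 nM, with an expected range from 3000 nM to 80000 nM.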

Compound 4, solubility: 165000 nM
Estimate against measurement, compound 4: 11-fold (1.04 log units) below; the whole stated range lies below it.
By their numbers in this assay, from the lowest: compound 3; then compounds 1 and 4 (each within the scatter of the next).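

In this assay, this position on the ring of carbon only proves able to carry a large rise: 4-methylpiperazin-1-yl on an aromatic carbon, para to a large group, gives an at least 33-fold higher number from compound 2 to compound 4 (1.51 log units; beyond the scatter). For the compounds shown here, the only earlier step, an at least 30-fold lower number from compound 1 to compound 2 (1.47 log units; beyond the scatter), came from a different change and ran downward, whereas this one runs upward with the trifluoromethyl still in place. Compound 2 reads a limit and not a number, so the printed size of the step is only a minimum: the limit of < 5000 nM in this assay, at which 1 of the 4 values shown sits.

As far as these compounds go, whether a morpholine or a dimethylamino group on the same aromatic carbon would move the read-out as far remains open. Also open, from the compounds shown here alone, is whether 4-methylpiperazin-1-yl would have a similar effect on compound 1, which carries no trifluoromethyl.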